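Swapping the fluorine pattern on a sulfonyl aryl group

This account rests on a few compounds, and the source may have more. Where it says the series, first, only, none or still open, it means among the compounds named here.

In an ADME assay on microsomes from liver (Homo sapiens) for metabolic stability, tested at 2.5 uM (a lower number here means slower removal, a higher number faster removal of the compound), two compounds have been measured. Compound 1 `O=S(=O)(c1cc(F)cc(F)c1)c1cnc2cc(F)ccc2c1-c1cccc(F)c1` gives 0.06 mL/min. Compound 2 `COc1ccc(-c2c(S(=O)(=O)c3ccc(F)cc3)cnc3cc(F)ccc23)cc1` gives 1.77 mL/min, the higher of the two numbers. The gap between compound 2 and compound 1 is wide and lies well beyond the usual scatter of this assay, so compound 2 is cleared markedly faster. The two compounds differ in more than one place, so nothing can be said about which part of the structure carries that gap.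

Compound 3 `COc1ccc(-c2c(S(=O)(=O)c3cc(F)cc(F)c3)cnc3cc(F)ccc23)cc1` has not yet been measured. It differs from compound 2 in one place: 3,5-difluorophenyl in place of 4-fluorophenyl on a sulfonyl sulfur. Among the measured compounds shown here, since no measured pair isolates this change, its effect is open; compound 1 carries the same 3,5-difluorophenyl group but also a different group elsewhere, so it cannot settle the point. A step from compound 2 to compound 3 of modest size, if any, is expected in this assay, estimated as a 1.5-fold lower number from compound 2 to compound 3 (0.17 log units; within the scatter), with a slight lean toward a lower number. Compound 3 is therefore estimated at 1.2 mL/min, within a range from 0.4 mL/min to 3 mL/min.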

Compound 3, intrinsic clearance in a liver preparation (reported as CLH), per the amount of preparation that the assay uses: 1.51 mL/min
Compound 3: the middle estimate sits 1.3-fold (0.10 log units) below what was measured; the range from low to high includes it.
By their numbers in this assay, from the lowest: compound 1; then compounds 3 and 2 (each within the scatter of the next).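

In this assay, with the 4-methoxyphenyl group held in place, putting 3,5-difluorophenyl in place of 4-fluorophenyl on the sulfonyl sulfur gives a 1.2-fold lower number from compound 2 to compound 3 (0.07 log units; within the scatter), so this swap does not separate the two compounds. Among the compounds shown here, with the 3,5-difluorophenyl group held in place instead, putting 4-methoxyphenyl in place of 3-fluorophenyl on the aromatic carbon gives a 25-fold higher number from compound 1 to compound 3 (1.40 log units; beyond the scatter), which is the first clean single change to move clearance beyond the scatter and shows that the outcome can turn on that other group. Nothing available explains either step.

Still open, from the compounds shown here alone, is whether the sulfonyl swap would stay just as quiet in a compound carrying 3-fluorophenyl on the aromatic carbon, since a quiet step alongside 4-methoxyphenyl need not carry over to a different neighbouring group. Also open, going by these compounds, is how far the sulfonyl sulfur tolerates something other than a fluorinated phenyl ring, such as a pyridine ring or a short alkyl chain, and whether a 4-hydroxyphenyl or a 4-aminophenyl group on the aromatic carbon would behave like 4-methoxyphenyl or like 3-fluorophenyl.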